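A few compounds are considered here, and "the series" means these few. Any claim that something is new, unique, unknown or untested is made for them only; others in the source may bear on it.

Three compounds share one core and differ only in the ring attached to the carbon that carries a double bond to nitrogen. Compound 1 `Oc1ccccc1/C=N/c1nnc(SCc2c[se]c(-c3ccccc3)n2)s1` holds a 2-hydroxyphenyl there, compound 2 `Oc1ccc(/C=N/c2nnc(SCc3c[se]c(-c4ccccc4)n3)s2)cc1` a 4-hydroxyphenyl, and compound 3 `Cc1ccc(/C=N/c2nnc(SCc3c[se]c(-c4ccccc4)n3)s2)cc1` a 4-methylphenyl. In a functional assay on MCF7 cells (Homo sapiens) for antiproliferative activity, read by CCK-8 assay (on this read-out higher numbers stand for weaker inhibition and lower numbers for stronger inhibition), compound 1 gives 15200 nM, compound 2 gives 31100 nM, and compound 3 gives 7550 nM. Compound 3 has the lowest number of the three, though the gap a 2.0-fold lower number from compound 1 to compound 3 (0.30 log units; within the scatter) lies within the scatter, while a 4.1-fold lower number from compound 2 to compound 3 (0.61 log units; beyond the scatter) lies beyond it.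

Compound 4 `O=[N+]([O-])c1ccc(/C=N/c2nnc(SCc3c[se]c(-c4ccccc4)n3)s2)cc1` is the next member: nitro in place of methyl on an aromatic carbon. The step that bears most directly on this change is a 4.1-fold lower number from compound 2 to compound 3 (0.61 log units; beyond the scatter), where a hydroxy on the same aromatic carbon was exchanged for the methyl. Among the measured compounds shown here, the moves a 2.0-fold higher number from compound 1 to compound 2 (0.31 log units; beyond the scatter) and a 2.0-fold lower number from compound 1 to compound 3 (0.30 log units; within the scatter) also touched only this ring. None of these steps introduced a nitro, so the direction of the new step is uncertain; the two other substituents tried on this carbon gave numbers that differ by a modest amount. The expectation for compound 4 is therefore a step of a 1.3-fold higher number from compound 3 to compound 4 (0.12 log units; within the scatter) in this assay, that is, an estimated 10000 nM with a range from 3500 nM to 30000 nM.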

Compound 4, half-maximal inhibitory concentration: 49100 nM
The estimate for compound 4 lay 4.9-fold (0.69 log units) below the measured number; measured number above the stated range.
By their numbers in this assay, from the lowest: compounds 3 and 1 (each within the scatter of the next); then compounds 2 and 4 (each within the scatter of the next).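

Exchanging methyl for nitro on this aromatic carbon is not a neutral swap: in this assay, a 6.5-fold higher number from compound 3 to compound 4 (0.81 log units; beyond the scatter) shows that the result depends strongly on which group sits there. Compound 4 cannot be separated from the hydroxy analogue, as a 1.6-fold higher number from compound 2 to compound 4 (0.20 log units; within the scatter) stays within the scatter, so the 4-methylphenyl of compound 3 is the one that stands apart from both of these para-substituted neighbours, while a 3.2-fold higher number from compound 1 to compound 4 (0.51 log units; beyond the scatter) changes the group and its place on the ring together and so cannot be credited to the nitro alone. No measurement available here explains why these groups differ.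

Four compounds cannot show whether a longer chain such as ethyl or propyl on this carbon would keep the number near that of compound 3, or where an amine or a carboxylic acid would fall. The rest of the shared core is the same in all four compounds, so they also leave open whether the effect of the group on this ring would hold if the other phenyl ring carried a substituent such as a chlorine.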